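A few compounds are considered here, and "the series" means these few. Any claim that something is new, unique, unknown or untested is made for them only; others in the source may bear on it.

Of the compounds shown here, three sharing one core have been measured in a functional assay on A-375 cells (Homo sapiens) for inhibition, read by MTT assay, with a stated time of 4 days; a higher number here means a weaker inhibitor, a lower number a stronger inhibitor. Compound 1 (`CN1C[C@@H]2C[C@H]1CN2c1cccc(-c2ccnc3c(-c4cccc5[nH]ncc45)c(-c4ccncc4)nn23)c1`) gives 1400 nM, compound 2 (`CN1C[C@@H]2CC[C@H]1CN2c1ccc(-c2ccnc3c(-c4cccc5[nH]ncc45)c(-c4ccncc4)nn23)cc1`) gives 185 nM, and compound 3 (`CN1C[C@@H]2CC[C@H]1CN2c1ccc(-c2ccnc3c(-c4cccc5[nH]ncc45)c(-c4ccncc4)nn23)c(F)c1`) gives 118 nM. Compound 3 therefore stands at the low end of the numbers, but it cannot be separated from compound 2, since a 1.6-fold lower number from compound 2 to compound 3 (0.20 log units; within the scatter) lies within the scatter. Its gap to compound 1 lies beyond the scatter.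

The next compound, compound 4 (`Fc1cc(CN2C3COCC2COC3)ccc1-c1ccnc2c(-c3cccc4[nH]ncc34)c(-c3ccncc3)nn12`), keeps the core and the fluoro group of compound 3 and alters the group on an aromatic carbon, meta to that fluoro group: a group of 10 heavy atoms (7 carbon, 1 nitrogen, 2 oxygen; 2 six-membered non-aromatic rings with 2 hetero atoms each) in place of a group of 9 heavy atoms (7 carbon, 2 nitrogen; one six-membered non-aromatic ring with 1 hetero atom, one six-membered non-aromatic ring with 2 hetero atoms), on an aromatic carbon. For the measured compounds named here, no measured step makes this replacement. The only one available, a 1.6-fold lower number from compound 2 to compound 3 (0.20 log units; within the scatter), concerns the fluoro group, which stays in place here, so it says little about the new group. Going by the values given here, the sole guide is the range of values among compounds carrying different groups, from compound 3 at 118 nM to compound 1 at 1400 nM, which shows that this assay can respond strongly when this part of the molecule differs. A modest loss is expected, with wide uncertainty. The expected change is a 2.5-fold higher number from compound 3 to compound 4 (0.41 log units; beyond the scatter), towards a higher number. For compound 4 the estimated value is 300 nM, with an expected range from 80 nM to 1100 nM.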

Compound 4, half-maximal inhibitory concentration: 304 nM
Estimate against measurement, compound 4: 1.0-fold (0.01 log units) below; the measured number falls inside the stated range.
By their numbers in this assay, from the lowest: compounds 3, 2 and 4 (each within the scatter of the next, the first and the last beyond it); then compound 1.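

In this assay, for the compounds shown here, the group of 10 heavy atoms on this aromatic carbon, meta to a fluoro group, gives a 2.6-fold higher number from compound 3 to compound 4 (0.41 log units; beyond the scatter) and so provides the first measured step at this position with the fluoro group held in place. The step is modest yet beyond the scatter, which shows that this position accepts a change in both the rings and their hetero atoms at a limited cost, with the group entering carrying oxygen in each of its two rings and no defined stereocentres. Nothing in the data bears on why the number rises, so the step stands here as an observation only.

The rings, the hetero atoms and the stereocentres all differ at once across this step, so the compounds shown do not assign the change to any one of these features, and a simple morpholine or piperidine at this position could begin to separate them. Going by these compounds, it also remains open how a primary amine or a carboxylic acid would fare here, and whether the new group behaves the same with hydrogen in place of the fluoro group.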